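Ester-to-amide exchange on the sulfur-linked side chain

The source may hold more compounds than are shown below. What is called first, only, known or untested is meant among the compounds shown, and "the series" means these compounds.

Measured in an assay on CHO-K1 cells for antagonist activity at transient receptor potential cation channel subfamily V member 1 (Homo sapiens), read by FLIPR; on this read-out higher numbers stand for weaker inhibition and lower numbers for stronger inhibition:
compound 1 `CC(C)CCSc1nc(C(F)(F)F)ccc1CNC(=O)C(C)c1ccc(NS(C)(=O)=O)c(F)c1`: 0.7 nM
compound 2 `COC(=O)CCSc1nc(C(F)(F)F)ccc1CNC(=O)C(C)c1ccc(NS(C)(=O)=O)c(F)c1`: 48.2 nM

Among the measured compounds shown here, compound 2 holds the highest of the two numbers, the single step being a 69-fold higher number from compound 1 to compound 2 (1.84 log units; beyond the scatter). Compound 3 `CC(C(=O)NCc1ccc(C(F)(F)F)nc1SCCC(=O)N1CCCC1)c1ccc(NS(C)(=O)=O)c(F)c1` differs from compound 2 by pyrrolidin-1-yl in place of methoxy on a carbonyl carbon. For the measured compounds named here, no measured step touches the group on this carbonyl carbon; the one step known changes the methoxycarbonyl against isopropyl and says nothing about what replaces the methoxy. The expected 1.6-fold lower number from compound 2 to compound 3 (0.21 log units; within the scatter) is therefore small and could run either way, with a wide range. Compound 3 is estimated at 30 nM (5 nM to 200 nM).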

Compound 3, inhibition constant: 85 nM
Estimate against measurement, compound 3: 2.8-fold (0.45 log units) below; measured number inside the range.
By their numbers in this assay, from the lowest: compound 1; then compounds 2 and 3 (each within the scatter of the next).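

Replacing methoxy with pyrrolidin-1-yl on the carbonyl carbon does not separate the two side chains in this assay (a 1.8-fold higher number from compound 2 to compound 3 (0.25 log units; within the scatter)), so methoxycarbonyl and (pyrrolidin-1-yl)carbonyl read alike at this position. The large gap to the isopropyl-ended chain of compound 1 remains with the amide as well (a 120-fold higher number from compound 1 to compound 3 (2.08 log units; beyond the scatter)). Nothing available explains either step.

Still open, from the compounds shown here alone, is how a carboxylic acid, a morpholine amide or a longer chain ending in a carbonyl would read here. Also open, going by these compounds, is whether any chain carrying a carbonyl can approach compound 1.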